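Capping a Phenol Oxygen in a Thiadiazole Series

The source may report more compounds than this note shows. Statements on the series, on what has been measured and on what is new or still open speak of the compounds shown alone.

Of the compounds shown here, three have been measured so far. Compound 1, `COc1cc(-c2nnc(SCc3ccc([N+](=O)[O-])cc3)o2)ccc1O`, gives 14200 nM in a functional assay on cells (T-cell, Mus musculus, strain BALB/c) for inhibition, read by MTT assay, with stated times of 24 h and 72 h; on this read-out higher numbers stand for weaker inhibition and lower numbers for stronger inhibition. Compound 2, `COc1cc(-c2nnc(SCc3ccc(Cl)cc3)o2)ccc1O`, gives 11100 nM. Compound 3, `COc1cc(-c2nnc(SCc3ccccc3)o2)ccc1O`, gives 1250 nM.

Among these, compound 2 sits near the top of the numbers: its nearest neighbour is compound 1, separated by a 1.3-fold lower number from compound 1 to compound 2 (0.11 log units; within the scatter), while compound 3 lies far off, separated by an 8.9-fold lower number from compound 2 to compound 3 (0.95 log units; beyond the scatter). Compound 1 to compound 3 spans an 11-fold lower number from compound 1 to compound 3 (1.06 log units; beyond the scatter).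

Compound 4, `COc1cc(-c2nnc(SCc3ccc(Cl)cc3)o2)ccc1OCc1ccc(Cl)cc1`, differs from compound 2 by 4-chlorobenzyl in place of hydrogen on an oxygen on an aromatic ring; read one bond further out, a hydroxy becomes a (4-chlorobenzyl)oxy. Going by the values given here, no measured step touches this oxygen: all three measured steps swap groups on the other benzyl ring. They therefore say nothing direct about compound 4, and no step beyond the scatter can be argued for from them.

Compound 4 is estimated at 11000 nM, within 3000 nM to 40000 nM, meaning an expected step of a 1.0-fold lower number from compound 2 to compound 4 (0.00 log units; within the scatter).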

Compound 4, half-maximal inhibitory concentration: 17200 nM
Compound 4: the middle estimate sits 1.6-fold (0.19 log units) below what was measured; measured number inside the range.
By their numbers in this assay, from the lowest: compound 3; then compounds 2, 1 and 4 (each within the scatter of the next).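

Capping the oxygen of compound 2 is the first change at this position, and in this assay it gives a 1.5-fold higher number from compound 2 to compound 4 (0.19 log units; within the scatter) and so leaves the number within the usual scatter. Even a change as large as hydroxy to (4-chlorobenzyl)oxy, which adds 8 heavy atoms and an aromatic ring and removes the hydrogen on this oxygen, therefore produces no readable shift in this one pair, though compound 2 was already among the weaker compounds. No measurement at hand explains this result.

As far as these compounds go, whether a much smaller cap such as methyl, or a chain ending in an amine, would give a step beyond the scatter at this oxygen remains open. From the compounds shown here alone, it is also open whether the same 4-chlorobenzyl group on this oxygen would leave the number unchanged on compound 3, which gives 1250 nM and carries no substituent on its benzyl ring.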